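Triazole substituent swaps on the shared core

The compounds below may be only part of what the source reports. "The series", "measured", "known", "first", "only" and "open" are said of these compounds alone.

Measured compounds in this series:
compound 1, `O=C1O[C@H]([C@@H](O)Cn2cc(CNS(=O)(=O)c3ccc(F)cc3)nn2)C(OCc2ccccc2)=C1OCc1ccccc1`, 22900 nM
compound 2, `CC(C)(C)c1cn(C[C@H](O)[C@H]2OC(=O)C(OCc3ccccc3)=C2OCc2ccccc2)nn1`, 28300 nM

In a functional assay on HCT-116 cells (Homo sapiens) for antiproliferative activity, read by MTT assay, with a stated time of 72 h (a lower number here means a stronger inhibitor, a higher number a weaker inhibitor), compound 1 gives 22900 nM, and in this assay compound 2 gives 28300 nM. Among the compounds with values here, on paper compound 2 carries the larger of the two numbers, but its only neighbour is compound 1 and the step of a 1.2-fold higher number from compound 1 to compound 2 (0.09 log units; within the scatter) lies within the scatter, so the two compounds cannot be separated by these data. That step swapped the (((4-fluorophenyl)sulfonyl)amino)methyl group for tert-butyl on an aromatic carbon without a step beyond the scatter.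

Compound 3, `COc1ccc(-c2cn(C[C@H](O)[C@H]3OC(=O)C(OCc4ccccc4)=C3OCc3ccccc3)nn2)cc1`, differs from compound 2 by 4-methoxyphenyl in place of tert-butyl on an aromatic carbon. Within the data shown here, the single measured step that bears on this position is a 1.2-fold higher number from compound 1 to compound 2 (0.09 log units; within the scatter), which stayed within the scatter even though the group exchanged was large. No other comparison at this position exists in the series. The expectation for this assay is therefore a step that does not exceed the scatter, with no direction claimed. For compound 3 the expected step is a 1.3-fold lower number from compound 2 to compound 3 (0.11 log units; within the scatter). Compound 3 is estimated at 22000 nM, with a range from 7000 nM to 65000 nM.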

Compound 3, half-maximal inhibitory concentration: > 100000 nM
Compound 3 ended at the assay's limit; the forecaster's own chance of this, stated with the estimate: 10%; middle value at least 4.5-fold (0.65 log units) away from the limit.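

In this assay compound 3 gives > 100000 nM, which is a limit of the assay and not a number: the limit of > 100000 nM in this assay, at which 1 of the 3 values shown sits.

Even so, the position is shown to respond to substitution, which the earlier pair could not show: 4-methoxyphenyl in place of tert-butyl gives an at least 3.5-fold higher number from compound 2 to compound 3 (0.54 log units; beyond the scatter), and 4-methoxyphenyl in place of (((4-fluorophenyl)sulfonyl)amino)methyl gives an at least 4.3-fold higher number from compound 1 to compound 3 (0.64 log units; beyond the scatter). Within the data shown here, both steps lie beyond the scatter, whereas the only earlier exchange at this aromatic carbon, a 1.2-fold higher number from compound 1 to compound 2 (0.09 log units; within the scatter), does not, so a change here is not always silent in this assay.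

The compounds shown do not tell whether the step belongs to the six-membered aromatic ring standing directly on the aromatic carbon or to its methoxy group, a question that plain phenyl and 4-hydroxyphenyl would bear on. Also open, as far as these compounds go, is how this position behaves with a primary amine, a carboxylic acid or a longer alkyl chain in place of these groups, and whether any group here can bring the number clearly below those of compound 1 and compound 2.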